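Adding a Methyl Branch to the Side Chain of Compound 2

This account rests on a few compounds, and the source may have more. Where it says the series, first, only, none or still open, it means among the compounds named here.

Compound 3 `CCC(C)NC1=NS(=O)(=O)c2cc(Cl)ccc2N1` carries a sec-butyl side chain on its core; in a functional assay on the whole organism with Rattus norvegicus as the target (on this read-out lower numbers stand for an effect already at smaller amounts and higher numbers for an effect only at larger amounts of compound), compound 3 gives 25 uM. Compound 1 `CC(C)C(C)NC1=NS(=O)(=O)c2cc(Cl)ccc2N1` differs from it by methyl in place of hydrogen on a saturated chain carbon bound to two saturated chain carbons, and in this assay compound 1 gives 32 uM. The step of a 1.3-fold higher number from compound 3 to compound 1 (0.11 log units; within the scatter) is therefore small. Compound 2 `CC(C)C(C)NC1=NS(=O)(=O)c2cnccc2N1` carries the same side chain as compound 1 on a different core; the difference between the two cores is not broken down here. In this assay compound 2 gives 302 uM, the highest of the three numbers and beyond the scatter from both compound 1 and compound 3.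

Compound 4 `CC(NC1=NS(=O)(=O)c2cnccc2N1)C(C)(C)C` has not yet been measured. It differs from compound 2 by methyl in place of hydrogen on a saturated chain carbon bound to three saturated chain carbons. For the measured compounds named here, this is the same kind of change as the one from compound 3 to compound 1, but not the same: there the place was a saturated chain carbon bound to two saturated chain carbons, here it is one bound to three. The earlier step of a 1.3-fold higher number from compound 3 to compound 1 (0.11 log units; within the scatter) lay within the scatter, and on that basis a step of similar size is expected, a 1.2-fold higher number from compound 2 to compound 4 (0.06 log units; within the scatter). Compound 4 is thus estimated to give 350 uM in this assay, most likely between 120 uM and 1000 uM.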

Compound 4, concentration for half-maximal effect: 104 uM
Compound 4: the middle estimate sits 3.4-fold (0.53 log units) above what was measured; measured number outside the range, below it.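

In this assay, adding the methyl gives a 2.9-fold lower number from compound 2 to compound 4 (0.46 log units; beyond the scatter). A step read on one core therefore did not predict the step on the other here: the same change on two cores in this assay, a 1.3-fold higher number (0.11 log units; within the scatter) from compound 3 to compound 1 and a 2.9-fold lower number (0.46 log units; beyond the scatter) from compound 2 to compound 4, 3.7-fold (0.57 log units) apart, beyond the scatter of two such steps. This does not show that the core alone sets the size of the step, since the two pairs also differ in where the methyl goes, on a saturated chain carbon bound to two saturated chain carbons in one pair and on one bound to three in the other, and a single pair on each core cannot separate these two differences.

The compounds shown leave open how the 1,2,2-trimethylpropyl side chain behaves on the core of compound 1, which would put the same change in the same place on both cores. They also leave open what a longer chain or an amine in the side chain would do on either core.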